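A Fluorine Added to the Central Ring of a Kinase Inhibitor

This account rests on a few compounds, and the source may have more. Where it says the series, first, only, none or still open, it means among the compounds named here.

Measured so far:
compound 1, `O=C(Nc1ccc(Nc2ncnc3c2OCCN3)cc1)Nc1cc(Cl)cc(Cl)c1`: 4480 nM
compound 2, `CC(C)(C)c1cc(NC(=O)Nc2ccc(Nc3ncnc4c3OCCN4)cc2)no1`: 58 nM

Both compounds were tested in an assay on isolated protein for inhibition of proto-oncogene tyrosine-protein kinase receptor Ret variant V804L (Homo sapiens), read by 33P incorporation, with stated times of 15 min and 40 min; a lower number here means a stronger inhibitor, a higher number a weaker inhibitor. Compound 1 gives 4480 nM, while compound 2 gives 58 nM, the lowest of the two numbers. Among the compounds with values here, the only measured step, a 77-fold lower number from compound 1 to compound 2 (1.89 log units; beyond the scatter), exchanged the group on the amide-type nitrogen at the far end of the molecule and was large.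

Compound 3, `CC(C)(C)c1cc(NC(=O)Nc2ccc(Nc3ncnc4c3OCCN4)c(F)c2)no1`, changes a different part of compound 2: fluoro in place of hydrogen on an aromatic carbon. The fluorine sits on the six-membered aromatic ring of carbon only that joins the urea to the shared core, at the position described as ortho to a large group and meta to a large group. Within the data shown here, no measured step touches this ring, so the large step from compound 1 to compound 2 does not speak to it directly. Adding one small fluorine is therefore expected to give a step of a 1.2-fold lower number from compound 2 to compound 3 (0.06 log units; within the scatter) within the scatter, in no clear direction. Compound 3 is estimated at 50 nM, in the range 20 nM to 150 nM.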

Compound 3, half-maximal inhibitory concentration: 27 nM
The estimate for compound 3 lay 1.9-fold (0.27 log units) above the measured number; measured number inside the range.
By their numbers in this assay, from the lowest: compound 3; then compound 2; then compound 1.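

The ring of carbon that joins the urea to the shared core is not a silent part of the molecule in this assay: fluoro in place of hydrogen on the aromatic carbon ortho to a large group and meta to a large group gives a 2.1-fold lower number from compound 2 to compound 3 (0.33 log units; beyond the scatter) and so lies just past the usual scatter. Within the data shown here, until now, the only measured change was at the far end of the molecule, where the much larger a 77-fold lower number from compound 1 to compound 2 (1.89 log units; beyond the scatter) came from exchanging a whole group, whereas here a single added atom shifts the number modestly and costs nothing in this assay. Nothing available bears on why the number falls at this position.

Going by these compounds, whether chloro, a methyl group or an amine on this same carbon would lower the number further or raise it again remains open, as does what fluoro would do on another carbon of this ring. Fluoro is also seen here only alongside 5-(tert-butyl)-1,2-oxazol-3-yl, so its effect alongside the 3,5-dichlorophenyl group of compound 1 is unknown.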